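Shifting a Fluorine on a Weakly Inhibiting Pair

The source may report more compounds than this note shows. Statements on the series, on what has been measured and on what is new or still open speak of the compounds shown alone.

Compound 1 `C/C(=N\N=C1/SCC(=O)N1Cc1cccc(F)c1)c1cccs1` and compound 2 `C/C(=N/N=C1\SCC(=O)N1Cc1ccccc1[N+](=O)[O-])c1cccs1` share one core. In a physicochemical assay, with a stated time of 30 min (on this read-out lower numbers stand for stronger inhibition and higher numbers for weaker inhibition), compound 1 gives 21100000 nM, the higher of the two numbers shown, while compound 2 gives 18100000 nM, a gap within the usual scatter. Compound 3 `C/C(=N\N=C1/SCC(=O)N1Cc1ccccc1F)c1cccs1` follows from compound 1 by one change: 2-fluorophenyl in place of 3-fluorophenyl on a saturated chain carbon bound to an amide-type nitrogen in a ring. Among the measured compounds shown here, no pair differing in one place has been measured, so the step cannot be read from known data. With compound 1 at 21100000 nM and compound 2 at 18100000 nM so close, little movement in this assay is expected, none beyond the scatter. Compound 3 is estimated at 20000000 nM, between 8000000 nM and 50000000 nM, an expected step of a 1.1-fold lower number from compound 1 to compound 3 (0.02 log units; within the scatter).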

Compound 3, half-maximal inhibitory concentration: 15700000 nM
The estimate for compound 3 lay 1.3-fold (0.11 log units) above the measured number; the range from low to high includes it.
By their numbers in this assay, from the lowest: compounds 3, 2 and 1 (each within the scatter of the next).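

Among the compounds shown here, this is the first pair that differs in one place. In this assay, 2-fluorophenyl in place of 3-fluorophenyl on a saturated chain carbon bound to an amide-type nitrogen in a ring gives a 1.3-fold lower number from compound 1 to compound 3 (0.13 log units; within the scatter) and so leaves the two fluorophenyl groups indistinguishable on this read-out. No measurement available here speaks to the origin of this result. Still open, on these data alone, is whether an amine or a carboxylic acid on the phenyl ring in place of fluorine, or a longer chain at this position, would move the number beyond the scatter.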